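The source may hold more compounds than are shown below. What is called first, only, known or untested is meant among the compounds shown, and "the series" means these compounds.

Of the compounds shown here, two have been measured in an ADME assay on HepG2 2.2.15 cells (Homo sapiens) for cytotoxicity, read by MTT assay, with a stated time of 9 days; on this read-out lower numbers stand for higher toxicity in this test and higher numbers for lower toxicity in this test: compound 1 `CCOC(=O)c1cc2c(CN3CCCC3)c(O)c(OC)cc2nc1C[S+]([O-])c1ccc(F)c(F)c1` gives 16.5 uM, and compound 2 `CCOC(=O)c1cc2c(Cn3ccnc3)c(O)c(OC)cc2nc1CSc1ccc(OC)c(OC)c1` gives 189 uM.

Compound 2 stands at the higher of the two numbers in this assay; its nearest neighbour is compound 1, and the gap between the two lies beyond the usual scatter. For the measured compounds named here, the two compounds differ in several places at once, so their values show only that compound 1 sits well below compound 2 and not what any single change contributes.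

Compound 3 `CCOC(=O)c1cc2c(Cn3ccnc3)c(O)c(OC)cc2nc1CSc1ccc(F)cc1` is the next compound to be measured. It differs from compound 2 in one place: 4-fluorophenyl in place of 3,4-dimethoxyphenyl on a sulfur. Going by the values given here, no pair of measured compounds isolates this change, so the expectation rests on the general spread seen between compound 1 and compound 2. In this assay a moderate step toward a lower number is expected for compound 3, a 1.9-fold lower number from compound 2 to compound 3 (0.28 log units; within the scatter). Compound 3 is therefore estimated at 100 uM in this assay, with a range from 35 uM to 250 uM.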

Compound 3, half-maximal toxic concentration: 202 uM
The estimate for compound 3 lay 2.0-fold (0.31 log units) below the measured number, and the stated range covers the measured number.
By their numbers in this assay, from the lowest: compound 1; then compounds 2 and 3 (each within the scatter of the next).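

In this assay, for the compounds shown here, the exchange of the aryl group gives a 1.1-fold higher number from compound 2 to compound 3 (0.03 log units; within the scatter), the first change in this set that can be read on its own. At this place, on a sulfur whose other neighbour is a saturated chain carbon, 3,4-dimethoxyphenyl and 4-fluorophenyl are therefore not told apart by this test, even though the two groups differ in heavy atoms and hydrogen-bond acceptors. No measured evidence bears on why the two groups read alike.

The compounds shown leave open whether a phenyl ring carrying a carboxylic acid or an amine on this sulfur, or a longer chain in place of the saturated chain carbon, would also stay within the scatter. They also leave open whether this same exchange would read alike on the rest of compound 1.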